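Carbonate in place of methyl ether on a thiolactone-free reading

The source may hold more compounds than are shown below. What is called first, only, known or untested is meant among the compounds shown, and "the series" means these compounds.

Results in a functional assay on MCF7 cells (Homo sapiens) for inhibition, read by radiometric assay and XTT assay (a higher number here means a weaker inhibitor, a lower number a stronger inhibitor), are these:
Compound 1 (`C=C/C(C)=C/[C@@]1(C)SC(=O)C=C1O`) gives > 80 ug/mL (a limit)
Compound 2 (`CCCCCC[C@@]1(C)SC(=O)C=C1OC`) gives 9.4 ug/mL
Compound 3 (`CCCCCCCC[C@@]1(C)SC(=O)C=C1OC`) gives 16.4 ug/mL

The value of compound 1 is a limit of the assay and not a number. Compound 3 stands level with compound 2 in this assay and the two lie within the scatter of each other. Compound 4 (`CCCCCCCC[C@@]1(C)SC(=O)C=C1OC(=O)OCC`) carries ethoxycarbonyl in place of methyl on an oxygen on an unsaturated carbon, so that methoxy becomes (ethoxycarbonyl)oxy. Going by the values given here, the one clean measured step is a 1.7-fold higher number from compound 2 to compound 3 (0.24 log units; within the scatter) and it concerns ethyl on a saturated chain carbon, not that oxygen. Compound 1 differs from compound 3 in more than one place and gives no clean guide. Among the compounds with values here, no measured step alters the group on that oxygen, so the expectation is loose. The estimated step of a 1.0-fold lower number from compound 3 to compound 4 (0.01 log units; within the scatter) is expected to stay within the scatter, in neither direction. For compound 4 the expected value is 16 ug/mL (estimated range 6 ug/mL to 45 ug/mL).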

Compound 4, half-maximal inhibitory concentration: 15.1 ug/mL
For compound 4 the middle estimate is 1.1-fold (0.03 log units) above the measured one; the measured number falls inside the stated range.
By their numbers in this assay, from the lowest: compounds 2, 4 and 3 (each within the scatter of the next). At a limit, above all of these: compound 1.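

In this assay, the group on the oxygen on an unsaturated carbon was changed from methyl to ethoxycarbonyl, and the step stays small: a 1.1-fold lower number from compound 3 to compound 4 (0.04 log units; within the scatter). This is the only measured change at that oxygen among the compounds shown, and it shows that methoxy and (ethoxycarbonyl)oxy cannot be told apart in this assay, even though the entering group has more heavy atoms and brings hydrogen-bond acceptors that methyl lacks. No measurement at hand bears on why the number holds.

Going by these compounds, it stays open whether a benzoyl group or a longer carbonate chain on that oxygen would also leave the number in place. On these data alone, it is also open whether ethoxycarbonyl would read the same on the shorter chain of compound 2.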